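This account rests on a few compounds, and the source may have more. Where it says the series, first, only, none or still open, it means among the compounds named here.

In an ADME assay on MDCK cells (Canis lupus familiaris) for permeability, in the apical to basolateral direction (a higher number here means that the compound crosses the layer faster, a lower number that the compound crosses the layer more slowly), compound 1 `CC(C)N=[S+](C)([O-])c1ccc(Nc2ncc(C(F)(F)F)c(N[C@@H]3CCC[C@H]3N(C)C)n2)cc1` gives 6.6 10^-6 cm/s, the only number shown for it, while one further entry for compound 1 carries no single number. Its close relative, compound 2 `CCN=[S+](C)([O-])c1ccc(Nc2ncc(C(F)(F)F)c(N[C@@H]3CCC[C@H]3N(C)C)n2)cc1`, gives 4.7 10^-6 cm/s; 8.3 10^-6 cm/s; 9.3 10^-6 cm/s (3 entries) across repeated entries, and the value of compound 1 falls inside that spread. Compound 3 `CN(C)[C@@H]1CCC[C@H]1Nc1nc(Nc2ccc(S(C)(=O)=O)cc2)ncc1C(F)(F)F` keeps the shared core but carries methylsulfonyl on the aromatic carbon, para to a large group, in place of the larger group found in compound 1: a group of 4 heavy atoms (1 carbon, 2 oxygen, 1 sulfur; no ring) in place of a group of 7 heavy atoms (4 carbon, 1 nitrogen, 1 oxygen, 1 sulfur; no ring), on an aromatic carbon. Among the measured compounds shown here, no measured pair isolates this change, so its size in this assay cannot be read from the data, and no step beyond the scatter is expected in either direction. With compound 1 at 6.6 10^-6 cm/s as the anchor, the expected change is small, a 1.1-fold higher number from compound 1 to compound 3 (0.06 log units; within the scatter). Compound 3 is therefore estimated at 7.5 10^-6 cm/s, with an expected range of 3.5 10^-6 cm/s to 15 10^-6 cm/s.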

Compound 3, apparent permeability: 9.5 10^-6 cm/s
Compound 3: middle estimate off by 1.3-fold (0.10 log units), on the low side; the range from low to high includes it.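

Swapping the larger group on the aromatic carbon, para to a large group, for methylsulfonyl gives the first reading of a change at this position in this assay, and it is small: a 1.4-fold higher number from compound 1 to compound 3 (0.16 log units; within the scatter). The two groups differ in size, yet the printed numbers do not separate them, so at this position in this assay the removal of the nitrogen-bearing group of compound 1 has no effect that can be told from the scatter. Repeated entries of a single compound spread at least as widely as this step: the several entries of compound 2 in this assay, 4.7 10^-6 cm/s; 8.3 10^-6 cm/s; 9.3 10^-6 cm/s (3 entries)

The compounds shown leave open whether a group of another kind on this aromatic carbon, such as an amine or a carboxylic acid, would give a step beyond the scatter in this assay. Changes elsewhere on the shared core also remain unread.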